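A few compounds are considered here, and "the series" means these few. Any claim that something is new, unique, unknown or untested is made for them only; others in the source may bear on it.

Measured so far in a functional assay on HEK293 cells for agonist activity at G-protein coupled receptor 39 (Homo sapiens), read by scintillation proximity assay and inositol phosphate accumulation, with a stated time of 75 min; on this read-out lower numbers stand for an effect already at smaller amounts and higher numbers for an effect only at larger amounts of compound:
- compound 1 `Cc1nn(-c2ncnc3nc[nH]c23)c2c1C(OCc1ccc(C(C)C)cc1)CC(=O)N2` — compound 1 gives 1690 nM
- compound 2 `Cc1nn(-c2ncnc3nc[nH]c23)c2c1C(OCc1ccc(C#N)cc1)CC(=O)N2` — compound 2 gives 60 nM
- compound 3 `Cc1nn(-c2ncnc3nc[nH]c23)c2c1C(OC(=O)c1ccc(F)cc1)CC(=O)N2` — compound 3 gives 245 nM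

Compound 2 stands lowest of the three numbers; the nearest is compound 3, the furthest compound 1, both steps beyond the scatter.

Compound 4 `Cc1nn(-c2ncnc3nc[nH]c23)c2c1C(OCc1cc(F)cc3c1OCOC3)CC(=O)N2` differs from compound 2 in one place: a group of 11 heavy atoms (8 carbon, 2 oxygen, 1 fluorine; one six-membered non-aromatic ring with 2 hetero atoms, one six-membered aromatic ring of carbon only) in place of a group of 8 heavy atoms (7 carbon, 1 nitrogen; one six-membered aromatic ring of carbon only), on a saturated chain carbon bound to an oxygen on a saturated carbon.

Of the measured steps, a 28-fold lower number from compound 1 to compound 2 (1.45 log units; beyond the scatter) bears most directly on this, since it also exchanges the group on the aromatic ring while keeping the saturated chain carbon bound to the oxygen; that step was large. The steps of a 4.1-fold higher number from compound 2 to compound 3 (0.61 log units; beyond the scatter) and a 6.9-fold lower number from compound 1 to compound 3 (0.84 log units; beyond the scatter) change the whole group on the oxygen and were modest. Within the data shown here, compound 4 gives up the cyano that compound 2 carries, and there is no measured compound with the entering group, so the direction cannot be read off firmly. A modest move to a higher number is expected for compound 4, a 4.2-fold higher number from compound 2 to compound 4 (0.62 log units; beyond the scatter), with wide uncertainty.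

Estimated for compound 4 in this assay: 250 nM, range 60 nM to 1000 nM.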

Compound 4, half-maximal effective concentration: 30 nM
Compound 4: the middle estimate sits 8.3-fold (0.92 log units) above what was measured; measured number below the stated range.
By their numbers in this assay, from the lowest: compounds 4 and 2 (each within the scatter of the next); then compound 3; then compound 1.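

In this assay, among these compounds, a 2.0-fold lower number from compound 2 to compound 4 (0.30 log units; within the scatter) shows that the 4-cyanophenyl is not the only group on the saturated chain carbon bound to an oxygen on a saturated carbon that goes with a low number, and that a nitrile is not required there. The group of 11 heavy atoms, with its fluorine and its six-membered non-aromatic ring, also stands well apart from the isopropyl-bearing group of compound 1: a 56-fold lower number from compound 1 to compound 4 (1.75 log units; beyond the scatter), a large step, as is a 28-fold lower number from compound 1 to compound 2 (1.45 log units; beyond the scatter). Nothing on hand accounts for these numbers.

The compounds shown do not separate the fluorine from the six-membered non-aromatic ring, as both enter together in compound 4. From the compounds shown here alone, how an amine or a carboxylic acid on the aromatic ring, or a longer chain in place of the saturated chain carbon, would read remains open.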